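A few compounds are considered here, and "the series" means these few. Any claim that something is new, unique, unknown or untested is made for them only; others in the source may bear on it.

Values in a physicochemical assay for lipophilicity, using the shake flask method, at pH 7.4 (on this read-out lower numbers stand for lower lipophilicity and higher numbers for higher lipophilicity), so far
compound 1 `CCCSc1ncccc1C(=O)NC1CCCCC1` gives 3.2
compound 2 `CCCSc1c(C(=O)NC2CCCCC2)cnn1C` gives 3

For the measured compounds named here, these are the only two numbers. Compound 2 (3) and compound 1 (3.2) lie within the usual scatter of each other, so neither can be placed ahead of the other.

Compound 3 `CCCSc1c(C(=O)NC2CCCCC2)cnn1-c1cccc(C(=O)O)c1` keeps the rest of compound 2 and carries 3-carboxyphenyl in place of methyl on an aromatic nitrogen. Going by the values given here, no measured pair shows an exchange of this kind, so the expectation rests on the structural change alone. A step well beyond the scatter, towards lower numbers in this assay, is expected, and it is estimated as a number 1.80 log units lower from compound 2 to compound 3 (beyond the scatter). For compound 3 the estimated value is 1.2 (expected range 0.5 to 2).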

Compound 3, distribution coefficient: 0.7
For compound 3 the middle estimate is 0.50 log units above the measured one, within the range that was stated.
By their numbers in this assay, from the lowest: compound 3; then compounds 2 and 1 (each within the scatter of the next).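

Notes on the series: in this assay, the group on the aromatic nitrogen, next to the ring atom that bears a propylsulfanyl group, proves able to shift the read-out, with the move to 3-carboxyphenyl from methyl giving a number 2.30 log units lower from compound 2 to compound 3 (beyond the scatter) as the first step the series can read. This shows that the position does not leave the value fixed, and that this one exchange carries compound 3 clear of the other two compounds. For the compounds shown here, the exchange brings in the six-membered aromatic ring and the carboxylic acid together, so the single step cannot be divided between them.

Still open, as far as these compounds go, is what an unsubstituted phenyl or a methyl ester in place of the acid would give on the same nitrogen. What lies behind the size of the step also stays open, as nothing at hand bears on it.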